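Terminal group of the aryloxy side chain

This account rests on a few compounds, and the source may have more. Where it says the series, first, only, none or still open, it means among the compounds named here.

Three members of the series have been run in a functional assay on cells for agonist activity at Free fatty acid receptor 1 (Homo sapiens), read by FLIPR and calcium flux; a higher number here means that more compound is needed for the effect, a lower number that less compound is needed. Compound 1 `CC#C[C@@H](Cc1nnn[nH]1)c1ccc(OCc2ccc3scc(-c4cccnc4C)c3c2)cc1` gives 88 nM. Compound 2 `CC#C[C@@H](Cc1nnn[nH]1)c1ccc(OCc2ccc3sc(F)c(-c4ccccc4C)c3c2)cc1` gives 15 nM. Compound 3 `CC#C[C@@H](Cc1nnn[nH]1)c1ccc(OCc2ccc3scc(-c4ccc(OCCCS(C)(=O)=O)cc4C)c3c2)cc1` gives 12 nM. Compound 3 therefore shows the lowest number of the three, but the gap to compound 2 lies within the scatter, so the two cannot be ordered; only compound 1 sits beyond the scatter from compound 3.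

The next analogue, compound 4 `CC#C[C@@H](Cc1nnn[nH]1)c1ccc(OCc2ccc3scc(-c4ccc(OCCC(C)(C)O)cc4C)c3c2)cc1`, keeps the core of compound 3 and the side chain on the pendant aryl ether, and differs only at the chain end: 1-hydroxy-1-methylethyl in place of (methylsulfonyl)methyl on a saturated chain carbon, two bonds along the chain from an oxygen on an aromatic ring. For the measured compounds named here, no pair among the measured compounds covers this kind of exchange, so there is no measured step to lean on; the chain length and the position of the attachment stay the same and only the terminus changes.

On that basis the step of a 1.3-fold higher number from compound 3 to compound 4 (0.12 log units; within the scatter) is expected to be small, at most a modest rise, and within the scatter. Compound 4 is therefore estimated at 16 nM in this assay, with a range from 5 nM to 50 nM.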

Compound 4, half-maximal effective concentration: 8 nM
For compound 4 the middle estimate is 2.0-fold (0.30 log units) above the measured one; the measured number falls inside the stated range.
By their numbers in this assay, from the lowest: compounds 4, 3 and 2 (each within the scatter of the next); then compound 1.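

In this assay, 3-hydroxy-3-methylbutoxy in place of 3-(methylsulfonyl)propoxy gives a 1.5-fold lower number from compound 3 to compound 4 (0.18 log units; within the scatter), so compound 3 and compound 4 cannot be ordered. For the compounds shown here, this is the only one-place step so far, and it shows that the chain end can lose the sulfur and both double bonds outside aromatic rings, and move from 0 to 1 hydrogen-bond donor, with no shift beyond the scatter; with 4 heavy atoms entering for 5, the number stays at the level set by compound 3. No measured evidence on these compounds accounts for the two termini reading alike.

From the compounds shown here alone, it remains open whether this holds for other termini on the same chain, such as a primary amine or a carboxylic acid, or for a longer chain carrying the same tertiary alcohol. One step on one core also leaves open whether 3-hydroxy-3-methylbutoxy would read the same way on a pendant aryl ring carrying a different substituent pattern, or with fluorine on the core as in compound 2.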